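The source may hold more compounds than are shown below. What is called first, only, known or untested is meant among the compounds shown, and "the series" means these compounds.

Measured so far in a physicochemical assay for solubility, read by HPLC, in phosphate buffer, measured as kinetic solubility, at pH 7.4; a higher number here means a more soluble compound, a lower number a less soluble compound:
compound 1 `CCC(=O)c1cc(-c2ccc(S(N)(=O)=O)cc2)n(-c2ccc(Cl)cc2)n1` gives 41900 nM
compound 2 `CCC(=O)c1cc(-c2ccc(S(N)(=O)=O)cc2)n(-c2ccccc2Cl)n1` gives 4700 nM
compound 3 `CCC(=O)c1cc(-c2ccc(S(N)(=O)=O)cc2)n(-c2ccc(Cl)cn2)n1` gives 33700 nM

Compound 1 has the highest of these three numbers, though compound 3 sits within the scatter of it; compound 2 is furthest away. Going by the values given here, the only steps beyond the scatter are an 8.9-fold lower number from compound 1 to compound 2 (0.95 log units; beyond the scatter) and its mirror a 7.2-fold higher number from compound 2 to compound 3 (0.86 log units; beyond the scatter), while a 1.2-fold lower number from compound 1 to compound 3 (0.09 log units; within the scatter) stays within the scatter. Compound 4 `CN(C(=O)c1cc(-c2ccc(S(N)(=O)=O)cc2)n(-c2ccc(Cl)cc2)n1)C1CC1` is not yet measured. It differs from compound 1 in that (cyclopropyl(methyl)amino in place of ethyl on a carbonyl carbon). Every measured step changes the group on the aromatic nitrogen, so none bears on a change at the carbonyl carbon. Among the compounds with values here, with no comparable step to lean on, a change of at most modest size in either direction is expected, a 1.2-fold lower number from compound 1 to compound 4 (0.08 log units; within the scatter). Compound 4 is therefore estimated at 35000 nM, within a range from 12000 nM to 100000 nM.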

Compound 4, solubility: 99600 nM
Estimate against measurement, compound 4: 2.8-fold (0.45 log units) below; measured number inside the range.
By their numbers in this assay, from the lowest: compound 2; then compounds 3 and 1 (each within the scatter of the next); then compound 4.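

Going by these compounds alone, at the carbonyl carbon, a position the earlier compounds left unchanged, the number in this assay also moves: putting cyclopropyl(methyl)amino in place of ethyl gives a 2.4-fold higher number from compound 1 to compound 4 (0.38 log units; beyond the scatter). So the group on the aromatic nitrogen is not the only place where a single change shifts this read-out beyond the scatter. Nothing available explains this step.

The compounds shown leave open whether the step belongs to the added nitrogen or to the cyclopropyl ring, which a dimethylamino group on that carbonyl carbon could help separate. As far as these compounds go, whether the same change acts alike with 2-chlorophenyl on the aromatic nitrogen also remains open.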